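Solubility notes: pyridinyl replacement on the pyrazolone core

The source may report more compounds than this note shows. Statements on the series, on what has been measured and on what is new or still open speak of the compounds shown alone.

Measured compounds and their solubility values:
compound 1 `Cn1cc(-c2cnc(NCc3c(F)ccc4c3CCO4)c3cn[nH]c(=O)c23)cn1`: 1000 nM
compound 2 `Fc1ccc2c(c1CNc1ncc(Oc3ccccc3)c3nncn13)CCO2`: 8000 nM
compound 3 `O=C(Nc1cnc(NCc2c(F)ccc3c2CCO3)n2cnnc12)c1ccccc1`: 2000 nM

In a physicochemical assay for solubility, read by LC-MS, in phosphate buffer, with a stated time of 24 h, at pH 7.4 (on this read-out lower numbers stand for lower solubility and higher numbers for higher solubility), compound 1 gives 1000 nM, the lowest of the three numbers. Compound 3 is nearest to it, with a number that lies within the scatter of that of compound 1, so no order between those two can be claimed. Compound 2 stands furthest, beyond the scatter. Among the compounds with values here, the only step between measured compounds that differ in one place is a 4.0-fold lower number from compound 2 to compound 3 (0.60 log units; beyond the scatter); it concerns the shared core of compounds 2 and 3, not the core of compound 1.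

Compound 4 `Cc1nc(CO)ccc1-c1cnc(NCc2c(F)ccc3c2CCO3)c2cn[nH]c(=O)c12` differs from compound 1 by 6-(hydroxymethyl)-2-methylpyridin-3-yl in place of 1-methyl-1H-pyrazol-4-yl on an aromatic carbon. Within the data shown here, no measured step bears on this change: the step from compound 2 to compound 3 alters a different group on a different core, and nothing among the measured compounds varies the group at this place. With no guidance from the data, the expectation for compound 4 in this assay is a step of no more than the scatter, in either direction. The estimate for compound 4 is 1500 nM, with a range from 500 nM to 5000 nM. This estimate corresponds to an expected step of a 1.5-fold higher number from compound 1 to compound 4 (0.18 log units; within the scatter).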

Compound 4, solubility: 3000 nM
The estimate for compound 4 lay 2.0-fold (0.30 log units) below the measured number, and the stated range covers the measured number.
By their numbers in this assay, from the lowest: compounds 1, 3 and 4 (each within the scatter of the next, the first and the last beyond it); then compound 2.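

At this aromatic carbon, para to a large group on the core of compound 1, this assay shows a 3.0-fold higher number from compound 1 to compound 4 (0.48 log units; beyond the scatter) on placing 6-(hydroxymethyl)-2-methylpyridin-3-yl where 1-methyl-1H-pyrazol-4-yl stood. The read-out at this position therefore responds to the group it carries, and the larger group does not bring a lower number here. The change is a composite, however, with a six-membered aromatic ring replacing a five-membered one and a hydroxymethyl group adding a hydrogen-bond donor, and no measurement at hand explains the step.

The compounds shown do not separate the contributions of the ring, the methyl group and the hydroxymethyl group, so the part of the exchange that carries the step remains unassigned. Also open, as far as these compounds go, is how the read-out would respond at this place to an amine, a carboxylic acid or a longer chain in place of the hydroxymethyl group, and whether the same exchange would give a step of similar size on the shared core of compounds 2 and 3.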